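The source may hold more compounds than are shown below. What is called first, only, known or untested is meant among the compounds shown, and "the series" means these compounds.

Working notes on the series in a functional assay on CNE cells (Homo sapiens) for cytotoxicity, read by MTT assay, with a stated time of 72 h; a lower number here means a stronger inhibitor, a higher number a weaker inhibitor. Three compounds have been run so far and a fourth is pending. Compound 1 `COc1ccc(NC(=O)COC(=O)/C=C/c2cc(OC)c(OCc3ccc(Cl)c(Cl)c3)c(OC)c2)cc1` gives only a limit of the assay, > 200000 nM, in this assay. Compound 2 `CCOc1ccc(COc2c(OC)cc(/C=C/C(=O)N3CCN(Cc4ccc(Cl)c(Cl)c4)CC3)cc2OC)cc1` likewise gives only a limit, > 200000 nM. Compound 3 `O=C(COC(=O)/C=C/c1ccc(O)c(O)c1)NN1CCOCC1` also returns only a limit, > 200000 nM, so no number is known for it. Compound 3 therefore stands at the same point as the other two: all three values shown sit at the limit of > 200000 nM in this assay, at which 3 of the 3 values shown sit, and no order among them can be read.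

The pending compound is compound 4 `COc1ccc(NC(=O)COC(=O)/C=C/c2ccc(O)c(O)c2)cc1`. It differs from compound 3 in one place: 4-methoxyphenyl in place of morpholin-4-yl on an amide-type nitrogen. The same 4-methoxyphenyl on an amide-type nitrogen is present in compound 1, which also gave only a limit, > 200000 nM.

Going by the values given here, no step between measured compounds is available, so the size of this change cannot be taken from the data. Given that every value so far sits at the limit (the limit of > 200000 nM in this assay, at which 3 of the 3 values shown sit), the step from compound 3 to compound 4 is expected to be none beyond the scatter, a step that the limit leaves unreadable from compound 3 to compound 4. Compound 4 is accordingly estimated at 300000 nM, with a range from 150000 nM to 1000000 nM, and most likely the assay will again report only a limit.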

Compound 4, half-maximal inhibitory concentration: > 200000 nM
Compound 4 ended at the assay's limit; the forecaster's own chance of this, stated with the estimate: 85%; the middle value is on the limit's open side.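

In this assay compound 4 gives > 200000 nM, which is a limit of the assay and not a number. No step can be read between compound 3 and compound 4, as all values shown stand at one limit: the limit of > 200000 nM in this assay, at which 4 of the 4 values shown sit.

The compounds shown leave open whether any structure in this series reaches a measurable value in this assay.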